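The source may report more compounds than this note shows. Statements on the series, on what has been measured and on what is new or still open speak of the compounds shown alone.

Compound 1, `CC(=O)c1ccc(NC(=O)N[C@H](C)c2ccccc2)cc1`: 84%
Compound 2, `C[C@@H](NC(=O)Nc1ccc(Br)cc1)c1ccccc1`: 87%

In an ADME assay on the whole organism with Oryza sativa as the target, tested at 10 uM (a higher number here means a weaker effect of the compound at the concentration tested, a lower number a stronger effect), compound 2 gives 87%, and compound 1 gives 84%; the step of a number 3 percentage points higher from compound 1 to compound 2 (within the scatter) separates them, so the two compounds stand together. Compound 3, `C[C@@H](NC(=O)Nc1ccc(I)cc1)c1ccccc1`, differs from compound 2 in one place: iodo in place of bromo on an aromatic carbon. Within the data shown here, the only measured step that bears on this, a number 3 percentage points higher from compound 1 to compound 2 (within the scatter), also exchanged one group for another on an aromatic carbon and barely moved the number. No step beyond the scatter is therefore expected here either. Compound 3 is estimated at 87%, with a range from 75% to 97%. The expected step is no change at the digits printed from compound 2 to compound 3 (within the scatter).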

Compound 3, a percentage reported as activity, at one concentration (the size of the read-out at that concentration, not a potency): 85%
Beside the measured number, compound 3's estimate is 2 percentage points above it; the measured number falls inside the stated range.
By their numbers in this assay, from the lowest: compounds 1, 3 and 2 (each within the scatter of the next).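

In this assay, iodo in place of bromo gives a number 2 percentage points lower from compound 2 to compound 3 (within the scatter) and iodo in place of acetyl gives a number 1 percentage points higher from compound 1 to compound 3 (within the scatter) on this same aromatic carbon. Acetyl, bromo and iodo, para to a large group, therefore all read alike, and a second exchange of one halogen for another adds no visible step. No evidence is available to explain this flat result. From the compounds shown here alone, it remains open whether an amine, a carboxylic acid or a longer chain at this place would give a step beyond the scatter. The same is open for these groups elsewhere on the ring.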